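The compounds below may be only part of what the source reports. "The series", "measured", "known", "first", "only" and "open" are said of these compounds alone.

Measured compounds:
Compound 1 `CN1C[C@@H](c2cccs2)[C@@]2(Cc3ccccc3C2=O)[C@@]12C(=O)Nc1ccccc12`: 49.9%
Compound 2 `COc1ccc([C@@H]2CN(C)[C@]3(C(=O)N(C)c4ccccc43)[C@]23Cc2ccccc2C3=O)cc1`: 46.9%

In a functional assay on the whole organism (strain Wister albino) for inhibition, with Rattus norvegicus as the target, read by paw edema, with a stated time of 1 h, at a dose of 50 mg/kg by the intraperitoneal route (a higher number here means more inhibition at the dose given (going by the name of the read-out), a lower number less inhibition), compound 1 gives 49.9%, and compound 2 gives 46.9%. Compound 2 holds the lower of the two numbers, but its nearest neighbour is compound 1, and the two values lie within the usual scatter of each other, so on this read-out the two compounds cannot be told apart. Among the compounds with values here, no pair of measured compounds differs in one place only, so no single structural step has yet been measured in this assay.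

Compound 3 `COc1ccc([C@@H]2CN(C)[C@]3(C(=O)Nc4ccccc43)[C@]23Cc2ccccc2C3=O)cc1` differs from compound 2 in one place: hydrogen in place of methyl on an amide-type nitrogen in a ring. Compound 1 also carries a hydrogen on its amide nitrogen, and its value in this assay sits within the scatter of compound 2; beyond that the two differ elsewhere as well, so only their two numbers can be compared. Within the data shown here, the data give no measured step of this kind, so its size is not known. The step from compound 2 to compound 3 is expected to be small, a number 2.1 percentage points higher from compound 2 to compound 3 (within the scatter), with no direction beyond the scatter. Compound 3 is estimated at 49%, with a range from 38% to 60%.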

Compound 3, a percentage reported as inhibition, in the whole organism at one dose (the size of the read-out at that dose, not a potency): 41.2%
Estimate against measurement, compound 3: 7.8 percentage points above, within the range that was stated.
By their numbers in this assay, from the lowest: compounds 3, 2 and 1 (each within the scatter of the next).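

With hydrogen in place of methyl on the amide-type nitrogen in the ring, the position now has a measured step in this assay, a number 5.7 percentage points lower from compound 2 to compound 3 (within the scatter), so on this read-out a methyl and a hydrogen at this nitrogen cannot be told apart. Within the data shown here, the same compound 3 also gives the first reading at the saturated ring carbon: 4-methoxyphenyl in place of thiophen-2-yl amounts to a number 8.7 percentage points lower from compound 1 to compound 3 (within the scatter), so the two aryl groups, with the amide hydrogen kept in both compounds, cannot be told apart in this assay either. No measurement is at hand that could explain the numbers at either position.

Left open is whether a larger group on the amide-type nitrogen, such as a benzyl or an acetyl, would give a step beyond the scatter, since hydrogen and methyl are the only two substituents seen there. As far as these compounds go, it is equally open whether a different group on the saturated ring carbon, such as a 4-chlorophenyl, a furan-2-yl or a pyridin-3-yl, would separate from the values seen so far at this single dose and time.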